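The source may hold more compounds than are shown below. What is called first, only, known or untested is meant among the compounds shown, and "the series" means these compounds.

Compound 3, `COC(=O)[C@H]1N=C(SCc2ccccc2)[C@H]2C(=O)N(c3ccccc3)C(=O)[C@H]21`, carries a benzylsulfanyl group on the shared core. In a functional assay for inhibition, tested at 100 uM (a higher number here means more inhibition at the concentration tested (going by the name of the read-out), a lower number less inhibition), compound 3 gives 76%, the lowest of the three numbers measured, though all three sit within the scatter of one another: compound 1, `CCCCSC1=N[C@@H](C(=O)OC)[C@@H]2C(=O)N(c3ccccc3)C(=O)[C@H]12`, gives 82%, and compound 2, `CCCSC1=N[C@H](C(=O)OC)[C@@H]2C(=O)N(c3ccccc3)C(=O)[C@H]12`, gives 86%. Going by the values given here, the one measured step that touches this part of the molecule, a number 10 percentage points lower from compound 2 to compound 3 (within the scatter), is the change from propylsulfanyl to benzylsulfanyl. Compound 4, `CCCCSC1=N[C@H](C(=O)OC)[C@@H]2C(=O)N(c3ccccc3)C(=O)[C@H]12`, reverses that direction: propyl in place of phenyl on a saturated chain carbon bound to a sulfur, so that benzylsulfanyl becomes butylsulfanyl. Compound 1 shares the butyl chain with compound 4 but differs at one stereocentre, and its value and that of compound 3 lie within the scatter of each other. Taking the small size of the step from compound 2 to compound 3 as the guide, the author expects compound 4 to move back up by about a number 8 percentage points higher from compound 3 to compound 4 (within the scatter), a shift that would not itself exceed the scatter. Compound 4 is therefore estimated at 84%, with a range from 74% to 92% in this assay.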

Compound 4, a percentage reported as inhibition, at one concentration (the size of the read-out at that concentration, not a potency): 89%
For compound 4 the middle estimate is 5 percentage points below the measured one; low and high end bracket the measured number.
By their numbers in this assay, from the lowest: compounds 3, 1, 2 and 4 (each within the scatter of the next, the first and the last beyond it).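

In this assay, going by these compounds alone, the change from benzylsulfanyl to butylsulfanyl gives a number 13 percentage points higher from compound 3 to compound 4 (beyond the scatter), the first step at this position to lie beyond the scatter, so the phenyl and propyl ends of the chain can now be told apart, if only modestly. Among the straight chains, methyl in place of hydrogen on a saturated chain carbon, three bonds along the chain from a sulfur, gives a number 3 percentage points higher from compound 2 to compound 4 (within the scatter), so propylsulfanyl and butylsulfanyl cannot be told apart. The step for the stereocentre at a saturated ring carbon, a number 7 percentage points higher from compound 1 to compound 4 (within the scatter), likewise shows no separation, and it isolates configuration alone: the fact that compounds 1 and 4 differ only in the configuration as drawn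

The compounds shown leave open whether a chain longer than butyl, or a chain ending in an amine or a carboxylic acid, would keep the number of compound 4. With one tested concentration, they also give no measure of potency for any of these chains.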